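A few compounds are considered here, and "the series" means these few. Any claim that something is new, unique, unknown or untested is made for them only; others in the source may bear on it.

Working notes on the sulfamate series built on the core of compound 1 `NS(=O)(=O)Oc1ccc2c(c1)CN(C(=O)c1ccc(N3CCCCC3)cc1)CC2`; in an assay on HEK293 cells for inhibition of Steryl-sulfatase (Homo sapiens), tested at 0.1 uM (on this read-out lower numbers stand for a weaker effect and higher numbers for a stronger effect at the one concentration tested), compound 1 gives 11.5%. Among the compounds with values here, compound 2 `CCN(Cc1ccncc1)c1ccc(C(=O)N2CCc3ccc(OS(N)(=O)=O)cc3C2)cc1` gives 47% in this assay, the higher of the two numbers so far; its only neighbour is compound 1, and the step of a number 35.5 percentage points higher from compound 1 to compound 2 (beyond the scatter) separates them.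

Compound 3 `CCN(Cc1cccc(Br)c1)c1ccc(C(=O)N2CCc3ccc(OS(N)(=O)=O)cc3C2)cc1` is still to be measured. Its difference from compound 2 is 3-bromophenyl in place of pyridin-4-yl on a saturated chain carbon bound to a nitrogen on an aromatic ring.

Within the data shown here, of the measured steps, only the one from compound 1 to compound 2 exists, and it replaces piperidin-1-yl with ethyl((pyridin-4-yl)methyl)amino on an aromatic carbon; it leaves the group on the saturated chain carbon untouched, so no measured step covers the exchange made in compound 3. The step of a number 35.5 percentage points higher from compound 1 to compound 2 (beyond the scatter) shows that changes around this nitrogen can shift the read-out by a large amount, but it gives no direction for pyridin-4-yl to 3-bromophenyl. Without a guide, the expectation for compound 3 in this assay is a step of a number 3 percentage points higher from compound 2 to compound 3 (within the scatter), nothing beyond the scatter. Compound 3 is therefore estimated at 50%, within a range from 25% to 75% that is kept wide for an untested change.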

Compound 3, a percentage reported as inhibition, at one concentration (the size of the read-out at that concentration, not a potency): 80.2%
Estimate against measurement, compound 3: 30.2 percentage points below; the measured number lies above the stated range.
By their numbers in this assay, from the lowest: compound 1; then compound 2; then compound 3.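

In this assay, the exchange of pyridin-4-yl for 3-bromophenyl on a saturated chain carbon bound to a nitrogen on an aromatic ring gives a number 33.2 percentage points higher from compound 2 to compound 3 (beyond the scatter), so the ring on this chain carbon, which the earlier pair left unexplored, strongly affects the read-out on its own. The full replacement of piperidin-1-yl by (3-bromobenzyl)(ethyl)amino on an aromatic carbon gives a number 68.7 percentage points higher from compound 1 to compound 3 (beyond the scatter), and this step is larger than the one seen with ethyl((pyridin-4-yl)methyl)amino at the same place. Nothing available on these compounds accounts for the size of either step.

The exchange swaps the ring nitrogen for carbon and adds bromine in a single move, so the compounds shown leave open how much of the step belongs to each, which plain phenyl or 3-chlorophenyl on the same chain carbon would help separate. Also open, as far as these compounds go, is whether the ethyl group on the nitrogen contributes to the read-out, a question that a longer chain such as propyl, or a methyl group, in its place would address.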